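Sulfone series: aryl swap on the alkene carbon

The source may report more compounds than this note shows. Statements on the series, on what has been measured and on what is new or still open speak of the compounds shown alone.

Going by the values given here, compound 1 `O=C(/C(=C\c1csc([N+](=O)[O-])c1)S(=O)(=O)c1ccc(Br)cc1)c1ccc(Br)cc1` holds the lowest of the three numbers so far in a functional assay on DU-145 cells (Homo sapiens) for inhibition, read by trypan blue exclusion, with a stated time of 96 h; a lower number here means a stronger inhibitor of growth, a higher number a weaker inhibitor of growth: compound 1 gives 1000 nM. Compound 2 `CN(C)c1ccc(/C=C(/SCc2ccc(Br)cc2)C(=O)c2ccc(C(=O)O)cc2)cc1` gives 50000 nM and compound 3 `Cc1ccc(CS/C(=C/c2ccc(F)cc2C(F)(F)F)C(=O)c2ccc(Cl)cc2)cc1` gives 50000 nM; both stand beyond the scatter from compound 1, but each differs from it in more than one place, so no single step can be read off them. Compound 4 `COc1ccc(/C=C(\C(=O)c2ccc(Br)cc2)S(=O)(=O)c2ccc(Br)cc2)c(F)c1` is the next member awaiting measurement in this assay. Its relation to compound 1 is 2-fluoro-4-methoxyphenyl in place of 5-nitrothiophen-3-yl on a double-bonded chain carbon bound to a double-bonded chain carbon. Among the compounds with values here, no measured pair isolates such a change, so the expected step is a moderate one toward a higher number, with little confidence in its size. Compound 4 is expected to give about 5000 nM, within 1000 nM to 30000 nM. That estimate corresponds to an expected step of a 5.0-fold higher number from compound 1 to compound 4 (0.70 log units; beyond the scatter).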

Compound 4, concentration for 50% growth inhibition: 10000 nM
The estimate for compound 4 lay 2.0-fold (0.30 log units) below the measured number; the measured number falls inside the stated range.
By their numbers in this assay, from the lowest: compound 1; then compound 4; then compounds 2 and 3 (each within the scatter of the next).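

On the double-bonded chain carbon bound to a double-bonded chain carbon, the sulfone series now has its first readable step in this assay: 2-fluoro-4-methoxyphenyl in place of 5-nitrothiophen-3-yl gives a 10-fold higher number from compound 1 to compound 4 (1.00 log units; beyond the scatter). This position is therefore not indifferent to the aryl group it carries. Nothing available accounts for the size of this step.

The swap changes the ring and its substituents together, leaving their separate contributions open. A plain phenyl ring or a thiophene without the nitro group at this position would begin to separate them.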